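Swapping Hydroxy for Carboxy: An Expectation for Compound 4

The compounds below may be only part of what the source reports. "The series", "measured", "known", "first", "only" and "open" are said of these compounds alone.

Of the compounds shown here, three sharing one core have been measured in a functional assay on A-375 cells (Homo sapiens) for antiproliferative activity, read by MTT assay, with a stated time of 24 h, tested at 0.41 ug/mL; on this read-out lower numbers stand for a weaker effect and higher numbers for a stronger effect at the one concentration tested. Compound 1 `Cc1c(C(=O)Nc2c(F)cc(-c3cccc(F)c3)cc2F)nc2ccc(F)cc2c1O` gives 0.86%, compound 2 `Cc1c(C(=O)Nc2c(F)cc(-c3cccc(F)c3)cc2F)nc2ccc(OC(F)(F)F)cc2c1O` gives 1.02%, and compound 3 `Cc1c(C(=O)Nc2c(F)cc(-c3cccc(F)c3)cc2F)nc2ccc(C(F)(F)F)cc2c1O` gives 16.5%. The first two sit within the scatter of each other, as the step of a number 0.2 percentage points higher from compound 1 to compound 2 (within the scatter) shows. Compound 3 stands highest of the three, because a number 15.6 percentage points higher from compound 1 to compound 3 (beyond the scatter) and a number 15.5 percentage points higher from compound 2 to compound 3 (beyond the scatter) both lie beyond the scatter.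

Compound 4 `Cc1c(C(=O)Nc2c(F)cc(-c3cccc(F)c3)cc2F)nc2ccc(C(F)(F)F)cc2c1C(=O)O` differs from compound 3 in one place: carboxy in place of hydroxy on an aromatic carbon. Among the measured compounds shown here, every measured step so far changed a different position of the core, exchanging fluoro, trifluoromethoxy and trifluoromethyl; none of them touched the hydroxy group, so no measured step bears directly on this change. The direction of the step from compound 3 to compound 4 is therefore open, and the estimate must be wide. A step of a number 4.5 percentage points lower from compound 3 to compound 4 (within the scatter) is expected, with considerable uncertainty. Compound 4 is estimated at 12% in this assay, between 0% and 35%.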

Compound 4, a percentage reported as inhibition, at one concentration (the size of the read-out at that concentration, not a potency): 7.82%
The estimate for compound 4 lay 4.2 percentage points above the measured number; the measured number falls inside the stated range.
By their numbers in this assay, from the lowest: compounds 1, 2, 4 and 3 (each within the scatter of the next, the first and the last beyond it).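

This is the first change shown at the position opposite the ring nitrogen, and swapping hydroxy for carboxy there in this assay gives a step of a number 8.7 percentage points lower from compound 3 to compound 4 (within the scatter). The two numbers cannot be told apart, so at this one concentration a group of three heavy atoms stands in for one of a single heavy atom with no change beyond the usual scatter. Nothing among the data shown explains this result.

The swap is shown only on the compound carrying trifluoromethyl, so whether it would give a similar result on the fluoro or trifluoromethoxy compounds remains open. Also open, on these data alone, is what other groups at this position would give, such as an amine, a methoxy group or a longer chain like an ethyl ester.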